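The source may hold more compounds than are shown below. What is called first, only, known or untested is meant among the compounds shown, and "the series" means these compounds.

Compound 1, `Nc1ccccc1NC(=O)c1ccc(CSC(=S)N2CCN(c3ccc(Cl)cc3)CC2)cc1`: 17.2%
Compound 2, `CCN(Cc1ccncc1)C(=S)SCc1ccc(C(=O)Nc2ccccc2N)cc1`: 85.2%
Compound 3, `Nc1ccccc1NC(=O)c1ccc(CSC(=S)N2CCc3ccc([N+](=O)[O-])cc32)cc1`: 39.6%

All three were measured in a functional assay on MGC-803 cells (Homo sapiens) for antiproliferative activity, read by CCK-8 assay, with a stated time of 72 h, tested at 8 uM; a lower number here means a weaker effect, a higher number a stronger effect of the compound at the concentration tested. Compound 1 stands lowest of the three: compound 3 lies above it beyond the scatter, and compound 2 lies far above it, also beyond the scatter. Compound 4, `Nc1ccccc1NC(=O)c1ccc(CSC(=S)N2CCN(Cc3ccccc3)CC2)cc1`, differs from compound 1 in one place: benzyl in place of 4-chlorophenyl on an amine nitrogen in a ring. Among the compounds with values here, no measured pair shows this change by itself, so its effect is not known from the data. On the numbers at hand, a moderate rise is expected, a number 20.8 percentage points higher from compound 1 to compound 4 (beyond the scatter), likely beyond the scatter but well short of what compound 2 shows. Compound 4 is therefore estimated at 38%, within a range from 14% to 68%.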

Compound 4, a percentage reported as inhibition, at one concentration (the size of the read-out at that concentration, not a potency): 19.7%
The estimate for compound 4 lay 18.3 percentage points above the measured number, within the range that was stated.
By their numbers in this assay, from the lowest: compounds 1 and 4 (each within the scatter of the next); then compound 3; then compound 2.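

In this assay, benzyl in place of 4-chlorophenyl on this amine nitrogen in a ring gives a number 2.5 percentage points higher from compound 1 to compound 4 (within the scatter). Between these two groups, then, the change by itself leaves no readable difference at this position, even though the benzyl group enters with one more carbon and without the chlorine. No measurement shown here offers an explanation for the two compounds reading alike. From the compounds shown here alone, what a longer chain such as phenethyl, or a group carrying a carboxylic acid, would do on this nitrogen remains open.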